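Replacing the Triazole Side Group of Compound 1

The source may hold more compounds than are shown below. What is called first, only, known or untested is meant among the compounds shown, and "the series" means these compounds.

In a functional assay on MCF7 cells (Homo sapiens) for cytotoxicity, read by MTT assay, with a stated time of 72 h (on this read-out higher numbers stand for weaker inhibition and lower numbers for stronger inhibition), compound 1 `O=C1c2c[n+]([O-])c3ccccc3c2C(=O)c2c1c1ccccc1n2Cc1cn(CC(O)CO)nn1` gives 1110 nM. Compound 2 `CC1(C)O[C@@H](CO)[C@H](Cn2cc(Cn3c4c(c5ccccc53)C(=O)c3c[n+]([O-])c5ccccc5c3C4=O)nn2)O1` gives 690 nM, so the two numbers lie within the scatter of each other and compound 1 has no clear standing apart from compound 2. Compound 3 `O=C1c2c[n+]([O-])c3ccccc3c2C(=O)c2c1c1ccccc1n2CCN1CCCCC1` has (piperidin-1-yl)methyl in place of 1-(2,3-dihydroxypropyl)-1H-1,2,3-triazol-4-yl on a saturated chain carbon bound to an aromatic nitrogen. Among the compounds with values here, the only measured step is small: a 1.6-fold lower number from compound 1 to compound 2 (0.21 log units; within the scatter). Within the data shown here, that step exchanges 1,2-dihydroxyethyl for 5-(hydroxymethyl)-2,2-dimethyl-1,3-dioxolan-4-yl, and no measured step removes the group that leaves here, so it offers only a loose guide. No change beyond the scatter is therefore firmly expected in this assay. The expected change is a 1.9-fold lower number from compound 1 to compound 3 (0.27 log units; within the scatter). The estimated value for compound 3 is 600 nM, with an expected range from 180 nM to 2000 nM.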

Compound 3, half-maximal inhibitory concentration: 620 nM
The estimate for compound 3 lay 1.0-fold (0.01 log units) below the measured number, and the stated range covers the measured number.
By their numbers in this assay, from the lowest: compounds 3, 2 and 1 (each within the scatter of the next).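

In this assay, putting (piperidin-1-yl)methyl in place of 1-(2,3-dihydroxypropyl)-1H-1,2,3-triazol-4-yl on a saturated chain carbon bound to an aromatic nitrogen gives a 1.8-fold lower number from compound 1 to compound 3 (0.25 log units; within the scatter), so this change does not separate the two compounds. The earlier step altered only the 1,2-dihydroxyethyl part and kept the five-membered aromatic ring, whereas this one replaces that ring with a six-membered non-aromatic ring and leaves 0 hydrogen-bond donors in the entering group. Across these compounds, then, neither the aromatic ring nor the hydrogen-bond donors of the group that leaves appear necessary for a number in this range, although nothing given here explains the result. From the compounds shown here alone, it remains open whether a carboxylic acid at the end of the chain, or an open-chain amine such as diethylamino, would move the number beyond the scatter. A longer chain between the shared core and the piperidine ring is equally untested by these compounds.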